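Swapping the amide ring from thiophene to pyridine

This account rests on a few compounds, and the source may have more. Where it says the series, first, only, none or still open, it means among the compounds named here.

Compound 1 `Cc1cc(C(=O)N[C@H]2CCN(Cc3ccc(OCCCN(C)C)cc3)C2)ccc1Cl` gives 631 nM in an assay on HEK293 cells for binding affinity to Urotensin-2 receptor (Homo sapiens), read by radioligand binding; a higher number here means a weaker inhibitor, a lower number a stronger inhibitor. Compound 2 `CN(C)CCCOc1ccc(CN2CC[C@H](NC(=O)c3cccs3)C2)cc1` reaches only a limit of the assay, < 10000 nM in this assay. Within the data shown here, the single measured step, a step that the limit leaves unreadable from compound 1 to compound 2, cannot be sized because of the limit of < 10000 nM in this assay, at which 1 of the 2 values shown sits. Compound 3 `CN(C)CCCOc1ccc(CN2CC[C@H](NC(=O)c3ccncc3)C2)cc1` differs from compound 2 by pyridin-4-yl in place of thiophen-2-yl on a carbonyl carbon. No readable step bears on this change, so compound 3 is expected to land close to where compound 2 sits. The step that the limit leaves unreadable from compound 2 to compound 3 is expected to be small. The estimate for compound 3 in this assay is 5000 nM, with a range from 1000 nM to 20000 nM.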

Compound 3, inhibition constant: < 10000 nM
Compound 3 ended at the assay's limit; the forecaster's own chance of this, stated with the estimate: 50%; the middle value lies beyond the limit too.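

Among these compounds, no step leading to compound 3, whether from compound 1 or from compound 2, can be read: the limit of < 10000 nM in this assay, at which 2 of the 3 values shown sit. The compounds shown leave open how strong compound 2 and compound 3 really are, and whether pyridin-4-yl and thiophen-2-yl differ at all.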